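A few compounds are considered here, and "the series" means these few. Any claim that something is new, unique, unknown or untested is made for them only; others in the source may bear on it.

Measured so far:
Compound 1 `COc1ccc(-n2nnnc2Nc2ccccc2Cl)cc1` — 134000 nM
Compound 2 `COc1ccc(Nc2nnnn2-c2cccc(Cl)c2)cc1` — 103000 nM
Compound 3 `COc1ccc(-n2nnnc2Nc2ccc(F)cc2)cc1` — 155000 nM

In an ADME assay on HaCaT cells (Homo sapiens) for cytotoxicity, read by MTT assay, with a stated time of 72 h (on this read-out lower numbers stand for stronger inhibition and higher numbers for weaker inhibition), compound 3 stands at the top of these three numbers, yet its gaps to compound 1 and compound 2 both fall within the usual scatter, so the three are best read as alike. Compound 4 `COc1ccc(-n2nnnc2Nc2ccccc2F)cc1` differs from compound 3 only in how the same atoms are joined: 2-fluorophenyl in place of 4-fluorophenyl on a nitrogen on an aromatic ring. Among the measured compounds shown here, one measured step touches this part of the molecule, a 1.2-fold higher number from compound 1 to compound 3 (0.06 log units; within the scatter), and it was small. With so little to go on, the step from compound 3 to compound 4 is expected to stay within the scatter, a 1.1-fold lower number from compound 3 to compound 4 (0.04 log units; within the scatter). Compound 4 is therefore estimated at 140000 nM, with a likely range from 75000 nM to 260000 nM.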

Compound 4, half-maximal inhibitory concentration: 111000 nM
The estimate for compound 4 lay 1.3-fold (0.10 log units) above the measured number, within the range that was stated.
By their numbers in this assay, from the lowest: compounds 2, 4, 1 and 3 (each within the scatter of the next).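

In this assay the place of the fluorine on the phenyl ring does not separate the compounds, with a 1.4-fold lower number from compound 3 to compound 4 (0.15 log units; within the scatter) when 2-fluorophenyl stands in place of 4-fluorophenyl. Fluoro in place of chloro on an aromatic carbon is just as small a change in the number, with a 1.2-fold lower number from compound 1 to compound 4 (0.08 log units; within the scatter) for that swap. No measurement shown here bears on these results.

Still open, on these data alone, is whether a group of another kind on this ring, such as an amine or a carboxylic acid, would give a clearly different number.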